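The source may hold more compounds than are shown below. What is called first, only, known or untested is meant among the compounds shown, and "the series" means these compounds.

Measured so far:
compound 1 `CCCOC(=O)C1=C(C)NC(=O)NC1c1ccoc1` — 50%
compound 2 `CC1=C(C(=O)NC(C)C)C(c2ccoc2)NC(=O)N1` — 1%

In an assay on membranes from CHO cells for displacement of a labelled ligand from adenosine receptor A1 (Homo sapiens), read by scintillation counting, with a stated time of 60 min, tested at 1 uM (on this read-out higher numbers stand for more inhibition at the one concentration tested (going by the name of the read-out) and lower numbers for less inhibition), compound 2 gives the lower of the two numbers, compound 1 standing higher by a number 49 percentage points lower from compound 1 to compound 2 (beyond the scatter). Compound 3 `CCC(C)OC(=O)C1=C(C)NC(=O)NC1c1ccoc1` differs from compound 2 as follows: sec-butoxy in place of isopropylamino on a carbonyl carbon. Among the measured compounds shown here, the one step that bears on this is the reverse move, propoxy to isopropylamino, which cost a number 49 percentage points lower from compound 1 to compound 2 (beyond the scatter). Going back from the amide to an alkoxy ester is therefore expected to recover most of that loss in this assay, though sec-butoxy is not the same alkoxy as propoxy, so the expected step is a number 44 percentage points higher from compound 2 to compound 3 (beyond the scatter). Compound 3 is estimated at 45%, within 20% to 70%.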

Compound 3, a percentage reported as inhibition, at one concentration (the size of the read-out at that concentration, not a potency): 13%
Beside the measured number, compound 3's estimate is 32 percentage points above it, and the stated range ends above it.
By their numbers in this assay, from the lowest: compound 2; then compound 3; then compound 1.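

In this assay an ester at this carbonyl carbon is not enough by itself: sec-butoxy in place of isopropylamino gives only a number 12 percentage points higher from compound 2 to compound 3 (beyond the scatter) and stays well short of compound 1. The alkoxy group also counts, as methyl in place of hydrogen on the saturated chain carbon bound to the oxygen gives a number 37 percentage points lower from compound 1 to compound 3 (beyond the scatter) and so the two esters are not interchangeable. Nothing at hand gives a reason for either step. Open, going by these compounds, is how a straight butoxy chain, an ethoxy group or a carboxylic acid at this carbonyl carbon would compare with propoxy. Also open, on these data alone, is whether a methylamino group would stand any nearer to the esters than isopropylamino.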